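Fluorines in Place of Methoxy Groups on the Aniline

This account rests on a few compounds, and the source may have more. Where it says the series, first, only, none or still open, it means among the compounds named here.

In a functional assay on DU-145 cells (Homo sapiens) for cytotoxicity, read by MTT assay, with a stated time of 48 h (on this read-out lower numbers stand for stronger inhibition and higher numbers for weaker inhibition), compound 3 `COc1ccc(N/C(CCNC2=CC(=O)c3ccccc3C2=O)=N\S(=O)(=O)c2ccc(C)cc2)cc1OC` gives 17800 nM, the second highest of three numbers. Compound 1 `Cc1ccc(S(=O)(=O)/N=C(/CCNC2=CC(=O)c3ccccc3C2=O)Nc2ccc(Cl)cc2)cc1` gives 32400 nM and compound 2 `Cc1ccc(S(=O)(=O)/N=C(/CCNC2=CC(=O)c3ccccc3C2=O)Nc2ccccc2[N+](=O)[O-])cc1` gives 7590 nM. The step of a 1.8-fold lower number from compound 1 to compound 3 (0.26 log units; within the scatter) lies within the scatter, whereas a 4.3-fold lower number from compound 1 to compound 2 (0.63 log units; beyond the scatter) and a 2.3-fold higher number from compound 2 to compound 3 (0.37 log units; beyond the scatter) are modest. Compound 4 `Cc1ccc(S(=O)(=O)/N=C(/CCNC2=CC(=O)c3ccccc3C2=O)Nc2ccc(F)c(F)c2)cc1` differs from compound 3 by 3,4-difluorophenyl in place of 3,4-dimethoxyphenyl on an amine nitrogen. Among the compounds with values here, only one measured step compares a 4-chlorophenyl with the 3,4-dimethoxyphenyl, namely a 1.8-fold lower number from compound 1 to compound 3 (0.26 log units; within the scatter), and it stayed within the scatter. For this assay no step beyond the scatter is therefore expected. Compound 4 is expected to give 20000 nM, between 8000 nM and 50000 nM, which would mean a 1.1-fold higher number from compound 3 to compound 4 (0.05 log units; within the scatter).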

Compound 4, half-maximal inhibitory concentration: 12900 nM
Estimate against measurement, compound 4: 1.6-fold (0.19 log units) above; low and high end bracket the measured number.
By their numbers in this assay, from the lowest: compounds 2, 4, 3 and 1 (each within the scatter of the next, the first and the last beyond it).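

In this assay, the position tolerates 3,4-difluorophenyl in place of 3,4-dimethoxyphenyl, a 1.4-fold lower number from compound 3 to compound 4 (0.14 log units; within the scatter), although the entering group has 0 hydrogen-bond acceptors and the leaving group 2. The new group also stays within the scatter of the 2-nitrophenyl group, a 1.7-fold higher number from compound 2 to compound 4 (0.23 log units; within the scatter), and becomes the second replacement to differ beyond the scatter from 4-chlorophenyl, a 2.5-fold lower number from compound 1 to compound 4 (0.40 log units; beyond the scatter). No measurement here explains these numbers. On these data alone, whether a carboxylic acid or an amine on this ring would move the number beyond the scatter remains open. So does replacing the ring with a longer alkyl chain.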